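This account rests on a few compounds, and the source may have more. Where it says the series, first, only, none or still open, it means among the compounds named here.

Measured so far:
compound 1, `COc1ccc(-c2cc(=O)c3c(OC)cc(OC)cc3n2C)cc1`, gives 28000 nM in a functional assay on SUP-B15 cells (Homo sapiens) for antiproliferative activity, with a stated time of 72 h; on this read-out higher numbers stand for an effect only at larger amounts of compound and lower numbers for an effect already at smaller amounts;
compound 2, `COc1ccc(-c2cc(=O)c3c(OC)cc(OC)cc3n2S(=O)(=O)c2ccc([N+](=O)[O-])cc2)cc1`, gives 17100 nM in this assay.

On these two numbers compound 2 stands lowest, with compound 1 as its nearest neighbour, though the two values lie within the usual scatter of each other. Compound 3, `COc1ccc(-c2cc(=O)c3c(OC)cc(OC)cc3n2S(=O)(=O)c2cc(Cl)cc(Cl)c2O)cc1`, has not yet been measured. It differs from compound 2 by 3,5-dichloro-2-hydroxyphenyl in place of 4-nitrophenyl on a sulfonyl sulfur. Within the data shown here, no measured step of this kind exists here, so the step from compound 2 to compound 3 is expected to be small, if any beyond the scatter, in this assay: a 1.4-fold lower number from compound 2 to compound 3 (0.15 log units; within the scatter). Compound 3 is therefore estimated at 12000 nM, between 4000 nM and 40000 nM.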

Compound 3, half-maximal effective concentration: > 37900 nM
Compound 3 gave a limit, no number (the forecaster's own chance of this, stated with the estimate: 10%); at least 3.1-fold (0.49 log units) between middle value and limit.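

The aryl group on a sulfonyl sulfur does matter in this assay: 3,5-dichloro-2-hydroxyphenyl in place of 4-nitrophenyl gives an at least 2.2-fold higher number from compound 2 to compound 3 (0.34 log units; beyond the scatter). Compound 1 and compound 2 lie within the scatter of each other, so the earlier pair showed no such sensitivity to change at this nitrogen-bound position. The result for compound 3 is a limit and not a number: the limit of > 37900 nM in this assay, at which 1 of the 3 values shown sits.

The compounds shown leave open whether the hydroxy group or the chlorine atoms account for this step, as they enter together. On these data alone, how an amine or a carboxylic acid on that aryl ring would read also remains open.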